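This account rests on a few compounds, and the source may have more. Where it says the series, first, only, none or still open, it means among the compounds named here.

Compound 1, `COc1cccc2c1c(C(=O)/C=C(\O)C(=O)O)cn2Cc1cccc(F)c1`, gives 65800 nM in an ADME assay on MT4 cells (Homo sapiens) for cytotoxicity, read by MTT assay; on this read-out higher numbers stand for lower toxicity in this test and lower numbers for higher toxicity in this test.
Compound 2, `COc1cccc2c1c(C(=O)/C=C(\O)C(=O)O)cn2Cc1c(F)ccc(F)c1F`, gives 49400 nM in this assay.
Compound 3, `CCOC(=O)/C(O)=C/C(=O)c1cn(Cc2cccc(F)c2)c2cccc(OC)c12`, gives 63200 nM in this assay.

On these three numbers compound 3 sits in the middle, with every gap within the scatter: the step from compound 1 to compound 3 is a 1.0-fold lower number from compound 1 to compound 3 (0.02 log units; within the scatter), and for the other pair compound 3 gives 63200 nM while compound 2 gives 49400 nM.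

Compound 4, `CCOC(=O)/C(O)=C/C(=O)c1cn(Cc2cc(F)cc(F)c2)c2cccc(OC)c12`, has not yet been measured. It differs from compound 3 by fluoro in place of hydrogen on an aromatic carbon.

Going by the values given here, one measured step bears on this: from compound 1 to compound 2 the change is also added fluoro groups on the same ring, and the result was a 1.3-fold lower number from compound 1 to compound 2 (0.12 log units; within the scatter). The step of a 1.0-fold lower number from compound 1 to compound 3 (0.02 log units; within the scatter) shows that the ethyl ester of compound 3 behaves like the acid of compound 1, so that comparison carries over. A single extra fluoro on this ring is therefore expected to leave the cytotoxicity essentially unchanged, with a step of a 1.1-fold lower number from compound 3 to compound 4 (0.06 log units; within the scatter) expected from compound 3 to compound 4.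

For compound 4 the expected value in this assay is 55000 nM, estimated to lie between 30000 nM and 100000 nM.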

Compound 4, half-maximal cytotoxic concentration: 34700 nM
For compound 4 the middle estimate is 1.6-fold (0.20 log units) above the measured one; the range from low to high includes it.
By their numbers in this assay, from the lowest: compounds 4, 2, 3 and 1 (each within the scatter of the next).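

Changing 3-fluorobenzyl to 3,5-difluorobenzyl on the ethyl ester gives a 1.8-fold lower number from compound 3 to compound 4 (0.26 log units; within the scatter) in this assay, so this aromatic carbon, meta to a fluoro group, can carry fluoro in place of hydrogen without a step that can be told apart from repeat-measurement noise. Together with a 1.3-fold lower number from compound 1 to compound 2 (0.12 log units; within the scatter), made on the acid with a different fluorination pattern, this gives two steps on this ring, one in each series, and neither rises above the scatter, so the fluoro changes shown on this ring have not separated any compounds on this read-out. Nothing shown here offers a measured explanation for the size of the new step.

Whether a chloro, a methyl or an amine on this same carbon would produce a step beyond the scatter stays open, since fluoro is the only group shown here. From the compounds shown here alone, it is also open whether 3,5-difluorobenzyl would give a similar result on the carboxylic acid in place of the ethyl ester, as the step from hydrogen to fluoro at this place is seen on the ester alone.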